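Working notes: from compound 1 to compound 3

The source may hold more compounds than are shown below. What is called first, only, known or untested is meant among the compounds shown, and "the series" means these compounds.

compound 1 `CCc1ccc(NC(=O)Nc2cc(C)nc3ccccc23)cc1` gives 16000 nM
compound 2 `Cc1cc(NC(=O)Nc2cc(F)cc(F)c2)c2ccccc2n1` gives > 25000 nM (a limit)

Among the measured compounds shown here, in an ADME assay on HEK293 cells (Homo sapiens) for cytotoxicity, with a stated time of 72 h (a lower number here means that less compound is needed, a higher number that more compound is needed for the effect), compound 1 gives 16000 nM and holds the only actual number so far. Compound 2 stands at > 25000 nM and this is a limit, not a number.

Compound 3 `Cc1cc(NC(=O)Nc2ccc(C(N)=O)cc2)c2ccccc2n1` is still unmeasured. It has carbamoyl in place of ethyl on an aromatic carbon, para to a large group (carbamoyl in place of ethyl on an aromatic carbon). For the measured compounds named here, no measured pair shows what this change does. With compound 1 at 16000 nM as the sole anchor, the expected 1.4-fold higher number from compound 1 to compound 3 (0.14 log units; within the scatter) is small and towards a higher number in this assay and may stay within the scatter. The estimate for compound 3 is 22000 nM with an expected range from 11000 nM to 35000 nM and a limit in place of a number is quite possible.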

Compound 3, half-maximal effective concentration: > 25000 nM
Compound 3 gave a limit, no number; the forecaster's own chance of this, stated with the estimate: 55%; middle value at least 1.1-fold (0.05 log units) from the limit.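

In this assay, among the compounds shown here, carbamoyl in place of ethyl, on an aromatic carbon para to a large group, gives an at least 1.5-fold higher number from compound 1 to compound 3 (0.19 log units; that floor lies within the scatter) and is the only step that can be read so far. With that floor inside the scatter, the step does not establish a real difference between the two groups at this position. On these data alone, it shows only that carbamoyl here does not bring the read-out to an actual number, and the true size of the step remains unknown because the series runs into an assay limit: the limit of > 25000 nM in this assay, at which 2 of the 3 values shown sit.

As far as these compounds go, whether an amine, a carboxylic acid or a longer chain at this position would give a number rather than a limit stays open. For the compounds shown here, compound 1 remains the only compound with an actual number, so no step of known size exists.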